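This account rests on a few compounds, and the source may have more. Where it says the series, first, only, none or still open, it means among the compounds named here.

Compound 3 `O=C(O)CCc1ccc(OCc2nnc(C(=O)Nc3ccc(F)c(F)c3)s2)cc1` was tested in a functional assay on CHO cells for agonist activity at Free fatty acid receptor 1 (Homo sapiens), read by calcium flux (a higher number here means that more compound is needed for the effect, a lower number that less compound is needed), where compound 3 gives 580 nM. Among the measured compounds shown here, this is the lowest of the three numbers so far, although a 1.8-fold lower number from compound 1 to compound 3 (0.26 log units; within the scatter) lies within the scatter; compound 1 `O=C(O)CCc1ccc(OCc2nnc(C(=O)Nc3ccccc3)s2)cc1` gives 1060 nM and compound 2 `Cc1cccc(NC(=O)c2nnc(COc3ccc(CCC(=O)O)cc3)s2)c1` gives 1770 nM. Compound 4 `Cc1ccc(NC(=O)c2nnc(COc3ccc(CCC(=O)O)cc3)s2)cc1` differs from compound 3 in one place: 4-methylphenyl in place of 3,4-difluorophenyl on an amide-type nitrogen. For the measured compounds named here, two measured steps bear on this change. Adding a methyl to the phenyl gave a 1.7-fold higher number from compound 1 to compound 2 (0.22 log units; within the scatter), and the move from a methylphenyl to the difluorophenyl gave a 3.1-fold lower number from compound 2 to compound 3 (0.48 log units; beyond the scatter). Reversing that direction, a step toward a higher number is expected, a 2.4-fold higher number from compound 3 to compound 4 (0.38 log units; beyond the scatter). Compound 4 is therefore expected to give about 1400 nM in this assay, with a range from 600 nM to 3500 nM.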

Compound 4, half-maximal effective concentration: 4300 nM
The estimate for compound 4 lay 3.1-fold (0.49 log units) below the measured number; the measured number lies above the stated range.
By their numbers in this assay, from the lowest: compounds 3, 1 and 2 (each within the scatter of the next, the first and the last beyond it); then compound 4.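

In this assay, among the compounds shown here, the group on the amide-type nitrogen proves more sensitive than the earlier compounds showed: 4-methylphenyl in place of 3,4-difluorophenyl gives a 7.4-fold higher number from compound 3 to compound 4 (0.87 log units; beyond the scatter), the largest step so far. Methyl in place of hydrogen now gives a 4.1-fold higher number from compound 1 to compound 4 (0.61 log units; beyond the scatter), whereas the earlier methyl step, a 1.7-fold higher number from compound 1 to compound 2 (0.22 log units; within the scatter), stayed within the scatter, and 4-methylphenyl in place of 3-methylphenyl gives a 2.4-fold higher number from compound 2 to compound 4 (0.39 log units; beyond the scatter), so where the methyl stands on the ring counts. Nothing measured here explains these differences. Left open is whether 4-fluorophenyl or 4-chlorophenyl on that nitrogen would give a number nearer that of compound 3 or that of compound 4.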